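Fixing the Undrawn Stereocentre of Compound 2

This account rests on a few compounds, and the source may have more. Where it says the series, first, only, none or still open, it means among the compounds named here.

In an ADME assay on MT4 cells (Homo sapiens) for cytotoxicity, read by MTT assay, with a stated time of 5 days (a higher number here means that more compound is tolerated, a lower number that less compound is tolerated), compound 2 `N#Cc1ccc(Nc2nccc(C(O)c3c(F)cc(-c4ccc(C#N)cc4)cc3F)n2)cc1` reads > 45500 nM, which is a limit of the assay and not a number. Compound 3 `N#Cc1ccc(Nc2nccc([C@H](O)c3c(F)cc(-c4ccc(C#N)cc4)cc3F)n2)cc1` differs only in its drawing: the two compounds have the same atoms and bonds; at least one stereo element is drawn with a configuration in one of them and without one in the other: 1 of 1 stereo elements differ; a stereocentre at a saturated chain carbon is drawn without a configuration in compound 2 and R in compound 3. Among the compounds with values here, the one relevant comparison is compound 1 `N#Cc1ccc(Nc2nccc([C@@H](O)c3c(F)cc(-c4ccc(C#N)cc4)cc3F)n2)cc1`, drawn S, which gives 8400 nM. That step, an at least 5.4-fold higher number from compound 1 to compound 2 (0.73 log units; beyond the scatter), lies beyond the scatter, but it concerns the S form, so it is a weak guide to the R form. A small move towards less tolerated, or none beyond the scatter, is therefore expected in this assay. The expected step is an at least 1.5-fold lower number from compound 2 to compound 3 (0.18 log units; that floor lies within the scatter). Compound 3 is estimated at 30000 nM, within 9000 nM to 60000 nM.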

Compound 3, half-maximal cytotoxic concentration: 28500 nM
Estimate against measurement, compound 3: 1.1-fold (0.02 log units) above; measured number inside the range.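

In this assay, within the data shown here, drawing this stereocentre R rather than S gives a 3.4-fold higher number from compound 1 to compound 3 (0.53 log units; beyond the scatter), and only one thing changes behind that step: the fact that compounds 1 and 3 differ only in the configuration as drawn. Compound 2 reads > 45500 nM, which is a limit and not a number. Against that limit the step is an at least 1.5-fold lower number from compound 2 to compound 3 (0.20 log units; that floor lies within the scatter), so the undrawn form and the R form cannot be put in order.

The compounds shown leave open why the two configurations differ in tolerance. They also leave open whether the gap survives if an amine or a methoxy group replaces the hydroxyl at this stereocentre.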